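Lengthening an Aromatic Side Chain: From Methyl to Propyl

The source may report more compounds than this note shows. Statements on the series, on what has been measured and on what is new or still open speak of the compounds shown alone.

Of the compounds shown here, three have been measured in an assay on HEK293 cells for inhibition of N-acylethanolamine-hydrolyzing acid amidase (Rattus norvegicus), read by LC-MS, with a stated time of 30 min; on this read-out lower numbers stand for stronger inhibition and higher numbers for weaker inhibition. Compound 1 `Cc1ccccc1CCCCCCC(=O)N1CCCC1` and compound 2 `Cc1cccc(CCCCCCC(=O)N2CCCC2)c1` both carry a methyl group on the aromatic ring and differ only in its placement. In this assay compound 1 gives 68400 nM, while compound 2 gives 8300 nM, the lowest of the two numbers and separated from compound 1 by a gap beyond the usual scatter. Compound 3 `O=C(O)c1ccc(CCCCCCC(=O)N2CCCC2)cc1` reaches only a limit of the assay, > 100000 nM. That value sits at the limit of > 100000 nM in this assay, at which 1 of the 3 values shown sits, so it sets no number against the other two.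

Compound 4 `CCCc1cccc(CCCCCCC(=O)N2CCCC2)c1` has not yet been measured. It differs from compound 2 by ethyl in place of hydrogen on a saturated chain carbon bound to an aromatic carbon, which reads, cut one bond further out, as methyl becoming propyl. Within the data shown here, nothing among the measured compounds shows the effect of lengthening this group, so the expected step of a 1.7-fold lower number from compound 2 to compound 4 (0.22 log units; within the scatter) is small and within the scatter. Compound 4 is therefore estimated at 5000 nM, with a plausible range from 1500 nM to 20000 nM.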

Compound 4, half-maximal inhibitory concentration: > 100000 nM
Compound 4 ended at the assay's limit; the forecaster's own chance of this, stated with the estimate: 5%; middle value at least 20-fold (1.30 log units) away from the limit.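

At this place on the shared core, the group proves far less tolerant than the opening estimate allowed: in this assay, methyl becoming propyl gives an at least 12-fold higher number from compound 2 to compound 4 (1.08 log units; beyond the scatter). Among these compounds, none of the earlier compounds changed the length of this group, so this is the first sign that adding ethyl here, only two carbons, can by itself carry a compound beyond the measurable range. The value of compound 4 is a limit of the assay and not a number, so the step gives only the smallest size the change can have: the limit of > 100000 nM in this assay, at which 2 of the 4 values shown sit.

The compounds shown leave open whether a shorter extension, an ethyl group in place of the methyl group, already costs as much. They also leave open whether a hydroxyl group at the end of the propyl group would alter the outcome.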